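Working notes: 4-chlorophenyl to 3-chlorophenyl on the amide-type nitrogen

The source may hold more compounds than are shown below. What is called first, only, known or untested is meant among the compounds shown, and "the series" means these compounds.

Measured so far in an ADME assay on MT4 cells (Homo sapiens) for cytotoxicity, read by MTT assay, with a stated time of 5 days; a higher number here means that more compound is tolerated, a lower number that less compound is tolerated (both values are limits):
- compound 1 `Cc1cnc(Nc2ccc(C#N)cc2)nc1OCC(=O)Nc1ccccc1F` gives > 331000 nM as a limit
- compound 2 `Cc1cnc(Nc2ccc(C#N)cc2)nc1OCC(=O)Nc1ccc(Cl)cc1` gives > 317000 nM as a limit

Compound 2 stands at > 317000 nM as a limit and not a number. Within the data shown here, the only measured step is a step that the two limits leave unreadable from compound 1 to compound 2 and it brings 4-chlorophenyl in place of 2-fluorophenyl on an amide-type nitrogen, so it offers no size to carry over. Compound 3 `Cc1cnc(Nc2ccc(C#N)cc2)nc1OCC(=O)Nc1cccc(Cl)c1` comes next, with 3-chlorophenyl in place of 4-chlorophenyl on an amide-type nitrogen as the counted difference: 3-chlorophenyl in place of 4-chlorophenyl on an amide-type nitrogen. No step beyond the scatter is therefore expected in this assay in either direction, and a further limit is the likeliest read-out. The estimated step is an at least 1.0-fold lower number from compound 2 to compound 3 (0.02 log units; that floor lies within the scatter) on this reading. For compound 3 the estimated value is 300000 nM with an expected range from 110000 nM to 350000 nM if a number is reported.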

Compound 3, half-maximal cytotoxic concentration: 144000 nM
Beside the measured number, compound 3's estimate is 2.1-fold (0.32 log units) above it; low and high end bracket the measured number.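

In this assay, among these compounds, compound 3 is the first compound of the series to give a number and not a limit, so the group on the amide-type nitrogen can shift how much compound is tolerated. The same atoms joined differently are enough: 3-chlorophenyl in place of 4-chlorophenyl gives an at least 2.2-fold lower number from compound 2 to compound 3 (0.34 log units; beyond the scatter), and 3-chlorophenyl in place of 2-fluorophenyl gives an at least 2.2-fold lower number from compound 1 to compound 3 (0.36 log units; beyond the scatter). The first of these sizes is only a floor, because compound 2 stands at a limit and not a number: the limit of > 317000 nM in this assay, at which 1 of the 3 values shown sits.

The step from compound 1 to compound 2 cannot be read, so the 4-chlorophenyl and 2-fluorophenyl groups stay unordered. Open too, from the compounds shown here alone, is whether 3-fluorophenyl, 3-methoxyphenyl or 3-aminophenyl on the amide-type nitrogen would follow 3-chlorophenyl in this assay.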